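From an Alkyne Ester to Aryl Triazole Esters

The compounds below may be only part of what the source reports. "The series", "measured", "known", "first", "only" and "open" are said of these compounds alone.

Compound 1 `C#CCOC(=O)/C(C)=C/CC/C(C)=C/CC/C(C)=C/CC[C@@H]1[C@@]2(C)CCC(=O)C(C)(C)[C@H]2CC[C@@]1(C)O` carries an ethynyl group on a saturated chain carbon bound to an oxygen next to a carbonyl group; in a functional assay on A549 cells (Homo sapiens) for antiproliferative activity, read by MTT assay, with a stated time of 48 h (on this read-out higher numbers stand for weaker inhibition and lower numbers for stronger inhibition), compound 1 gives 45100 nM. Compound 2 `C/C(=C\CC/C(C)=C/CC[C@@H]1[C@@]2(C)CCC(=O)C(C)(C)[C@H]2CC[C@@]1(C)O)CC/C=C(\C)C(=O)OCc1cn(-c2ccccc2C)nn1` has a 1-(2-methylphenyl)-1H-1,2,3-triazol-4-yl group in place of that ethynyl. For compound 2 this assay reports only the limit > 150000 nM, which is not a number. Compound 3 `C/C(=C\CC/C(C)=C/CC[C@@H]1[C@@]2(C)CCC(=O)C(C)(C)[C@H]2CC[C@@]1(C)O)CC/C=C(\C)C(=O)OCc1cn(-c2cccc(Br)c2)nn1` instead carries a 1-(3-bromophenyl)-1H-1,2,3-triazol-4-yl group. For compound 3 this assay likewise reports only the limit > 150000 nM. Compound 3 thus stands at the limit of > 150000 nM in this assay, at which 2 of the 3 values shown sit, and nothing more precise is known about it. The measured steps read an at least 3.3-fold higher number from compound 1 to compound 2 (0.52 log units; beyond the scatter) and an at least 3.3-fold higher number from compound 1 to compound 3 (0.52 log units; beyond the scatter), both beyond the scatter, while the step that the two limits leave unreadable from compound 2 to compound 3 cannot be sized.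

Compound 4 `C/C(=C\CC/C(C)=C/CC[C@@H]1[C@@]2(C)CCC(=O)C(C)(C)[C@H]2CC[C@@]1(C)O)CC/C=C(\C)C(=O)OCc1cn(-c2ccc(C)cc2)nn1` is not yet measured. It differs from compound 3 in one place: 4-methylphenyl in place of 3-bromophenyl on an aromatic nitrogen. Going by the values given here, the only step of the same kind, a step that the two limits leave unreadable from compound 2 to compound 3, joins two limits and gives neither size nor direction. Compound 2 and compound 3 both sit at the limit. Compound 4 is therefore expected to stay there as well, with an expected step that the limit leaves unreadable from compound 3 to compound 4 and no change beyond the scatter. The estimate for compound 4 is 220000 nM, within 70000 nM to 700000 nM, and most probably it will again be reported only as a limit.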

Compound 4, half-maximal inhibitory concentration: > 150000 nM
Compound 4: a limit, no number (the forecaster's own chance of this, stated with the estimate: 80%); the middle value is on the limit's open side.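

Swapping the ethynyl group for 1-(4-methylphenyl)-1H-1,2,3-triazol-4-yl gives an at least 3.3-fold higher number from compound 1 to compound 4 (0.52 log units; beyond the scatter), and this third aryl group on the triazole nitrogen repeats the weakening already seen with 2-methylphenyl and 3-bromophenyl. In this assay compound 4 gives > 150000 nM, which is a limit of the assay and not a number. Among the three aryl triazole esters, none goes against this pattern, and exchanging the aryl group, whether methyl-bearing or bromine-bearing, produces no measurable value, so they share one reading: the limit of > 150000 nM in this assay, at which 3 of the 4 values shown sit.

The steps among compound 2, compound 3 and compound 4 cannot be read, so any real differences among these aryl groups remain hidden behind the limit. From the compounds shown here alone, it also stays open whether the weakening belongs to the triazole itself or to the aryl group on it, and whether a triazole carrying a simple methyl group, or a phenyl ring bearing an amine or a carboxylic acid, would return a measurable value.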